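The source may report more compounds than this note shows. Statements on the series, on what has been measured and on what is new or still open speak of the compounds shown alone.

Measured compounds:
compound 1, `COc1ccccc1-c1csc(N/N=C/c2cc(OC)c(OC)c(Br)c2Br)n1`, 85100 nM;
compound 2, `COc1cc(/C=N/Nc2nc(-c3cccc(Br)c3)cs2)c(Br)c(Br)c1OC`, 37000 nM;
compound 3, `COc1cc(/C=N/Nc2nc(-c3ccc(C(F)(F)F)cc3)cs2)cc(Br)c1OC`, 18300 nM.

In a functional assay on A549 cells (Homo sapiens) for inhibition, read by MTT assay, with a stated time of 48 h (a lower number here means a stronger inhibitor, a higher number a weaker inhibitor), compound 3 stands lowest of the three numbers: compound 2 is nearest, compound 1 furthest, and both gaps lie beyond the scatter, so compound 3 is the strongest inhibitor measured here. Compound 4, `COc1cc(/C=N/Nc2nc(-c3ccc(C(F)(F)F)cc3)cs2)c(Br)c(Br)c1OC`, differs from compound 3 by bromo in place of hydrogen on an aromatic carbon. For the measured compounds named here, the only measured step, a 2.3-fold lower number from compound 1 to compound 2 (0.36 log units; beyond the scatter), changes the aryl group on the shared core, not this position, so nothing measured bears directly on the change. Compound 1 and compound 2 both carry the bromo group, yet differ from compound 3 in a second place too. Compound 4 is therefore expected to sit close to compound 3, with a 1.2-fold lower number from compound 3 to compound 4 (0.09 log units; within the scatter) not beyond the scatter, at an estimated 15000 nM (range 6000 nM to 40000 nM).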

Compound 4, half-maximal inhibitory concentration: 17600 nM
Beside the measured number, compound 4's estimate is 1.2-fold (0.07 log units) below it; the measured number falls inside the stated range.
By their numbers in this assay, from the lowest: compounds 4 and 3 (each within the scatter of the next); then compound 2; then compound 1.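

In this assay, bromo in place of hydrogen on this aromatic carbon, ortho to a bromo group, leaves the number within the scatter (a 1.0-fold lower number from compound 3 to compound 4 (0.02 log units; within the scatter)), so this position accepts a second bromo without a readable change. With both bromo groups kept, the aryl group does matter: 4-(trifluoromethyl)phenyl gives a lower number than 3-bromophenyl (a 2.1-fold lower number from compound 2 to compound 4 (0.32 log units; beyond the scatter)) and than 2-methoxyphenyl (a 4.8-fold lower number from compound 1 to compound 4 (0.68 log units; beyond the scatter)). No measurement shown here explains these results. Open, going by these compounds, is whether an amine or a carboxylic acid on this carbon would shift the number, and whether the bromo change reads the same with another aryl group.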